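Dibromo-fluorophenyl sulfonamide: expected affinity from three measured analogues

A few compounds are considered here, and "the series" means these few. Any claim that something is new, unique, unknown or untested is made for them only; others in the source may bear on it.

Measured compounds:
compound 1, `COc1ccc(S(=O)(=O)Nc2cccc(Br)c2)cc1N1CCNCC1`, 1.26 nM
compound 2, `COc1ccc(S(=O)(=O)Nc2cc(Cl)cc(Cl)c2)cc1N1CCNCC1`, 0.631 nM
compound 3, `COc1ccc(S(=O)(=O)Nc2ccc(C)cc2Br)cc1N1CCNCC1`, 7.94 nM

In an assay on isolated protein for binding affinity to 5-hydroxytryptamine receptor 6 (Homo sapiens) (on this read-out higher numbers stand for weaker inhibition and lower numbers for stronger inhibition), compound 1 stands second highest of the three numbers; the nearest is the step of a 2.0-fold lower number from compound 1 to compound 2 (0.30 log units; within the scatter), the furthest the step of a 6.3-fold higher number from compound 1 to compound 3 (0.80 log units; beyond the scatter). Compound 4, `COc1ccc(S(=O)(=O)Nc2cc(Br)cc(Br)c2F)cc1N1CCNCC1`, has not yet been measured; it differs from compound 1 in one place: 3,5-dibromo-2-fluorophenyl in place of 3-bromophenyl on a sulfonamide nitrogen.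

For the measured compounds named here, two measured steps bear on this change. The 3,5-dichlorophenyl of compound 2 resembles the 3,5-dibromo pattern of compound 4, and that step stayed within the scatter. Compound 3 carries a halogen at the 2-position of its 2-bromo-4-methylphenyl, and there the number rose beyond the scatter, as did the step of a 13-fold higher number from compound 2 to compound 3 (1.10 log units; beyond the scatter). Compound 4 combines the 3,5-dihalogen pattern with a 2-fluoro, so a rise is expected, smaller than that seen for compound 3 since fluorine replaces bromine at that position and the 3,5-dibromo part alone would be expected to change little. The expected step is a 2.0-fold higher number from compound 1 to compound 4 (0.30 log units; within the scatter). Compound 4 is therefore estimated at 2.5 nM, in a range from 0.7 nM to 8 nM.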

Compound 4, inhibition constant: 2.51 nM
Compound 4: middle estimate off by 1.0-fold (0.00 log units), on the low side; low and high end bracket the measured number.
By their numbers in this assay, from the lowest: compounds 2, 1 and 4 (each within the scatter of the next, the first and the last beyond it); then compound 3.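

In this assay, the position on the sulfonamide nitrogen accepts 3,5-dibromo-2-fluorophenyl in place of 3-bromophenyl with no change beyond the scatter (a 2.0-fold higher number from compound 1 to compound 4 (0.30 log units; within the scatter)), so a group whose name carries a 2-halogen need not bring the rise seen with compound 3. The new group nevertheless parts from both other neighbours, lying on the favourable side of 2-bromo-4-methylphenyl (a 3.2-fold lower number from compound 3 to compound 4 (0.50 log units; beyond the scatter)) but on the unfavourable side of 3,5-dichlorophenyl (a 4.0-fold higher number from compound 2 to compound 4 (0.60 log units; beyond the scatter)), which places compound 4 in the gap between compound 2 and compound 3 and shows that this position can separate groups that look alike. Nothing measured here explains the size of these steps.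

Because 3,5-dibromo-2-fluorophenyl differs from each of the other groups in more than one substituent, the compounds shown cannot assign any of these steps to the fluorine or to the bromines alone, and a plain 2-fluorophenyl or 3,5-dibromophenyl would be needed to separate them. Also open, from the compounds shown here alone, is how this position would answer to a group of another kind on the phenyl ring, such as a nitrile, an amine or a carboxylic acid.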